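The source may hold more compounds than are shown below. What is called first, only, known or untested is meant among the compounds shown, and "the series" means these compounds.

Measured in a functional assay on KB cells (Homo sapiens) for cytotoxicity, read by sulforhodamine B assay; a higher number here means a weaker inhibitor, a lower number a stronger inhibitor:

- compound 1 `C=C1[C@@H](OC(C)=O)C[C@@H]2[C@](C)(COC=O)[C@H](OC(C)=O)CC[C@@]2(C)[C@@H]1C[C@@H](Nc1cccc(F)c1)C1=CCOC1=O`: 28600 nM
- compound 2 `C=C1[C@@H](OC(C)=O)C[C@@H]2[C@](C)(COC=O)[C@H](OC(C)=O)CC[C@@]2(C)[C@@H]1C[C@@H](Nc1ccc(O)cc1)C1=CCOC1=O`: 28900 nM
- compound 3 `C=C1[C@@H](OC(C)=O)C[C@@H]2[C@](C)(CO[Si](C)(C)C(C)(C)C)[C@H](OC(C)=O)CC[C@@]2(C)[C@@H]1C[C@@H](Nc1cccc(F)c1)C1=CCOC1=O`: 4560 nM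

Compound 3 has the lowest number of the three in this assay, and compound 1 and compound 2 sit level with each other well above it. The one directly measured route to compound 3 is a 6.3-fold lower number from compound 1 to compound 3 (0.80 log units; beyond the scatter), a change on an oxygen on a saturated carbon, which compound 4 leaves untouched.

Compound 4 `C=C1[C@@H](OC(C)=O)C[C@@H]2[C@](C)(CO[Si](C)(C)C(C)(C)C)[C@H](OC(C)=O)CC[C@@]2(C)[C@@H]1C[C@@H](Nc1cccc(OC)c1)C1=CCOC1=O` keeps that change and alters only the aromatic ring: methoxy in place of fluoro on an aromatic carbon. This is methoxy in place of fluoro on an aromatic carbon, meta to a large group, so that 3-fluorophenyl becomes 3-methoxyphenyl.

The closest evidence is a 1.0-fold higher number from compound 1 to compound 2 (0.00 log units; within the scatter), where 4-hydroxyphenyl replaced 3-fluorophenyl on the amine nitrogen. For the measured compounds named here, that single comparison was made on the other substitution at the oxygen, and no measured compound carries methoxy, so the support is thin. On this evidence, no shift beyond the scatter is expected in this assay, and the number should stay near that of compound 3.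

The expected outcome is a 1.1-fold higher number from compound 3 to compound 4 (0.02 log units; within the scatter). For compound 4 the estimated value is 4800 nM, with an expected range of 2000 nM to 11000 nM.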

Compound 4, half-maximal inhibitory concentration: 45200 nM
The estimate for compound 4 lay 9.4-fold (0.97 log units) below the measured number; measured number above the stated range.
By their numbers in this assay, from the lowest: compound 3; then compounds 1, 2 and 4 (each within the scatter of the next).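

In this assay the substituent on the aromatic ring can clearly move the number: with the silicon-bearing group on the oxygen held fixed, methoxy in place of fluoro gives a 9.9-fold higher number from compound 3 to compound 4 (1.00 log units; beyond the scatter) and is therefore not a neutral exchange on this background. The only earlier ring change, a 1.0-fold higher number from compound 1 to compound 2 (0.00 log units; within the scatter) and within the scatter, was made with the other group on the oxygen and had shown no sensitivity to the ring, so the two ring steps together show that not every ring change at this amine nitrogen is silent. The new step also runs in the opposite direction to a 6.3-fold lower number from compound 1 to compound 3 (0.80 log units; beyond the scatter) and shows that the lower number of compound 3 does not survive this ring change, but nothing shown here gives a reason for the shift.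

The compounds shown leave open whether methoxy would produce the same shift alongside the smaller group on the oxygen that compound 1 carries, since the two changes are seen together only in compound 4. They also leave open how a 3-chlorophenyl, 3-hydroxyphenyl or 3-ethoxyphenyl group would behave on the amine nitrogen, and whether the position follows any order among such groups.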